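Nitro diaryl ether amides: variation at the amide nitrogen

The source may hold more compounds than are shown below. What is called first, only, known or untested is meant among the compounds shown, and "the series" means these compounds.

Measured so far:
Compound 1 `CCN(C(=O)c1cc([N+](=O)[O-])ccc1Oc1ccc(OC)cc1)c1ccc(Cl)cc1`: 8300 nM
Compound 2 `COc1ccc(Oc2ccc([N+](=O)[O-])cc2C(=O)Nc2cccc(S(N)(=O)=O)c2)cc1`: 9900 nM

In a functional assay (Homo sapiens) for inhibition, using a membrane potential dye, in the presence of a further agent that is not named here (a higher number here means a weaker inhibitor, a lower number a stronger inhibitor), compound 2 gives 9900 nM. Compound 1 gives 8300 nM. The two numbers lie within the scatter of each other, so compound 2 is not set apart from compound 1 in this assay. Compound 3 `COc1ccc(NC(=O)c2cc([N+](=O)[O-])ccc2Oc2ccc(OC)cc2)cc1` carries 4-methoxyphenyl in place of 3-sulfamoylphenyl on an amide-type nitrogen. Among the compounds with values here, no step between measured compounds covers a change of this kind, so the step from compound 2 to compound 3 is estimated as a 1.3-fold lower number from compound 2 to compound 3 (0.12 log units; within the scatter), not clearly beyond the scatter in either direction. Compound 3 is expected to give 7500 nM, with a range from 2500 nM to 22000 nM.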

Compound 3, half-maximal inhibitory concentration: 3400 nM
For compound 3 the middle estimate is 2.2-fold (0.34 log units) above the measured one; measured number inside the range.
By their numbers in this assay, from the lowest: compound 3; then compounds 1 and 2 (each within the scatter of the next).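

In this assay the group on the amide-type nitrogen now separates compounds, with 4-methoxyphenyl in place of 3-sulfamoylphenyl giving a 2.9-fold lower number from compound 2 to compound 3 (0.46 log units; beyond the scatter). (4-Methoxyphenyl)amino in place of (4-chlorophenyl)(ethyl)amino on the carbonyl carbon gives a 2.4-fold lower number from compound 1 to compound 3 (0.39 log units; beyond the scatter), whereas compound 1 and compound 2 alone lay within the scatter of each other. No measurement at hand bears on the reason for either step.

Still open, as far as these compounds go, is which part of the second change carries its step, the ethyl group or the exchange of 4-chlorophenyl for 4-methoxyphenyl. Also open, from the compounds shown here alone, is how a carboxylic acid or a dimethylamino group on that phenyl ring would compare with compound 3.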